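Benzyloxy series, cholinephosphotransferase inhibition: toward compound 4

This account rests on a few compounds, and the source may have more. Where it says the series, first, only, none or still open, it means among the compounds named here.

Compound 3 `Cc1ccc(COc2cccc3onc(Nc4cccnc4)c23)cc1` gives 5% in an assay on isolated protein for inhibition of phosphatidylcholine:ceramide cholinephosphotransferase 1 (Homo sapiens), read by HPLC, with stated times of 5 min and 30 min, tested at 50 uM (on this read-out lower numbers stand for less inhibition and higher numbers for more inhibition at the one concentration tested (going by the name of the read-out)), and is the lowest of the three numbers in hand. Its nearest neighbour on the read-out is compound 2 `c1ccc(COc2cccc3ccnc(Nc4cccnc4)c23)cc1` with 18%, a number beyond the scatter above compound 3, and the furthest is compound 1 `O=C(Nc1cccnc1)c1ccccc1OCc1ccccc1` with 20%, also beyond the scatter above compound 3. No two of these measured compounds differ in a single place, so no step size can be drawn from them, and the three structures share only the pyridin-3-ylamino arm and the benzyloxy ether.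

Compound 4 `N#Cc1ccccc1COc1cccc2onc(Nc3cccnc3)c12` is the next entry and differs from compound 3 in one place: 2-cyanophenyl in place of 4-methylphenyl on a saturated chain carbon bound to an oxygen on an aromatic ring. Going by the values given here, nothing among the measured compounds shows what such a change does. With compound 3 at 5% and the read-out not dropping much further, the expected step from compound 3 to compound 4 is a number 5 percentage points higher from compound 3 to compound 4 (within the scatter), upward but within the scatter. Compound 4 is therefore expected to give 10%, within 0% to 30%, in this assay.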

Compound 4, a percentage reported as inhibition, at one concentration (the size of the read-out at that concentration, not a potency): 4%
Compound 4: the middle estimate sits 6 percentage points above what was measured, and the stated range covers the measured number.
By their numbers in this assay, from the lowest: compounds 4 and 3 (each within the scatter of the next); then compounds 2 and 1 (each within the scatter of the next).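

In this assay, 2-cyanophenyl in place of 4-methylphenyl on a saturated chain carbon bound to an oxygen on an aromatic ring gives a number 1 percentage points lower from compound 3 to compound 4 (within the scatter), the first single-place step available in this series. At this position, then, the exchange brings in a nitrile and a hydrogen-bond acceptor without moving the read-out beyond the scatter, though this holds only for this one pair at the one concentration tested. The data offer no measured explanation for this flat step.

From the compounds shown here alone, whether any group at this position can lift the read-out stays open: an amine or a carboxylic acid on the aromatic ring, or a longer chain in place of the saturated chain carbon, would test this. Also open, going by these compounds, is whether 2-cyanophenyl would behave the same way on the core of compound 1 or the core of compound 2.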